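The source may report more compounds than this note shows. Statements on the series, on what has been measured and on what is new or still open speak of the compounds shown alone.

Of the compounds shown here, two built on a shared core have been measured so far. Compound 1, `NC1=NC2(CCSCC2)N(OCCCOc2cccc(Cl)c2)C(N)=N1`, gives 260 nM in a functional assay on HL-60 cells (Homo sapiens) for antiproliferative activity, read by MTT assay, with a stated time of 72 h; on this read-out higher numbers stand for weaker inhibition and lower numbers for stronger inhibition. Compound 2, `NC1=NC2(CCOCC2)N(OCCCOc2cccc(Cl)c2)C(N)=N1`, gives 520 nM in this assay. Of these two numbers compound 2 has the higher one, and compound 1 is its nearest neighbour; the gap between them lies within the usual scatter of repeated measurements, so on this evidence the two compounds cannot be told apart.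

Compound 3, `NC1=NC2(CCOCC2)N(OCCCOc2ccc(Cl)c(Cl)c2)C(N)=N1`, has not yet been measured. It differs from compound 2 in one place: chloro in place of hydrogen on an aromatic carbon. Within the data shown here, no pair of measured compounds shows a change of this kind, so there is nothing here from which the size of its effect can be read directly. The expected step, a 1.5-fold lower number from compound 2 to compound 3 (0.17 log units; within the scatter), points toward a somewhat lower number in this assay, small enough that it may not clear the scatter. On that basis compound 3 is expected to give about 350 nM in this assay, with a likely range from 120 nM to 1000 nM.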

Compound 3, half-maximal inhibitory concentration: 1240 nM
The estimate for compound 3 lay 3.5-fold (0.55 log units) below the measured number; the measured number lies above the stated range.
By their numbers in this assay, from the lowest: compounds 1 and 2 (each within the scatter of the next); then compound 3.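

Putting chloro in place of hydrogen on this aromatic carbon, ortho to a chloro group and para to a large group, gives a 2.4-fold higher number from compound 2 to compound 3 (0.38 log units; beyond the scatter) in this assay and so weakens inhibition. This is the first single change among these compounds whose effect clears the scatter, and it shows that this carbon of the ring is not indifferent to substitution: turning 3-chlorophenyl into 3,4-dichlorophenyl moves the number upward, and the step is modest but real. No accompanying measurement says what lies behind this step.

As far as these compounds go, whether the weaker inhibition belongs to chloro in particular or would also follow from another group on the same carbon stays open, and a fluoro, a methyl, a methoxy or an amine in that place would be needed to tell these apart. From the compounds shown here alone, it also stays open whether the same change would give a step of similar size on the core of compound 1, the other compound measured with the 3-chlorophenyl group.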